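A few compounds are considered here, and "the series" means these few. Any claim that something is new, unique, unknown or untested is made for them only; others in the source may bear on it.

Measured so far in a physicochemical assay for solubility (a higher number here means a more soluble compound, a lower number a less soluble compound), where each value is a limit of the assay and not a number:

- Compound 1 `O=C(O)c1ccc(C(=O)/C(=C\c2ccc(Cl)c([N+](=O)[O-])c2)SCc2ccc(Cl)cc2)cc1`: < 1000 ug/mL
- Compound 2 `O=C(O)c1ccc(C(=O)/C(=C\c2ccc(Cl)c([N+](=O)[O-])c2)SCc2ccc(Br)cc2)cc1`: < 1000 ug/mL
- Compound 3 `O=C(O)c1ccc(C(=O)/C(=C\c2ccc(Cl)c([N+](=O)[O-])c2)SCc2ccccc2F)cc1`: < 1000 ug/mL

Compound 3 gives < 1000 ug/mL, which is a limit and not a number. It has no place in a ranking, since the whole set stands at the limit of < 1000 ug/mL in this assay, at which 3 of the 3 values shown sit.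

Compound 4 `O=C(O)c1ccc(C(=O)/C(=C\c2ccc(Cl)c([N+](=O)[O-])c2)S(=O)(=O)Cc2ccc(Br)cc2)cc1` changes one group of compound 3, on a double-bonded chain carbon bound to a carbonyl carbon and a double-bonded chain carbon. There, (4-bromobenzyl)sulfonyl stands in place of (2-fluorobenzyl)sulfanyl: (4-bromobenzyl)sulfonyl in place of (2-fluorobenzyl)sulfanyl on a double-bonded chain carbon bound to a carbonyl carbon and a double-bonded chain carbon.

The closest measured comparison for the benzyl part of this change is a step that the two limits leave unreadable from compound 2 to compound 3. The other two, a step that the two limits leave unreadable from compound 1 to compound 2 and a step that the two limits leave unreadable from compound 1 to compound 3, give no size either. Among the compounds with values here, no measured step covers sulfonyl in place of sulfanyl. With no readable size to carry over, no step beyond the usual scatter is expected in this assay, and this is a cautious default rather than a finding. The expected result is a number no lower from compound 3 to compound 4 (the limit leaves the size open). Compound 4 is estimated at 1000 ug/mL, with an expected range of 500 ug/mL to 2000 ug/mL, and the assay may well report only a limit again.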

Compound 4, solubility: < 1000 ug/mL
Compound 4: only a limit was reported; the forecaster's own chance of this, stated with the estimate: 90%; the middle value sits exactly at the limit.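

In this assay compound 4 gives < 1000 ug/mL, which is a limit and not a number. Within the data shown here, its steps from compound 1, compound 2 and compound 3 cannot be read, so no new step emerges. The compounds shown leave open how these four rank and how far sulfonyl in place of sulfanyl shifts the result in this assay.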